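This account rests on a few compounds, and the source may have more. Where it says the series, first, only, none or still open, it means among the compounds named here.

Compound 1 `Cc1ccccc1NC(=O)Nc1cc(C(C)(C)C)nn1-c1ccccc1` gives 7.1 degrees C in an assay on isolated protein for inhibition of STE20-like serine/threonine-protein kinase (Homo sapiens), read by thermal shift assay, tested at 10 uM; on this read-out higher numbers stand for stronger stabilisation of the target against heat and lower numbers for weaker stabilisation of the target.
Compound 2 `CC(C)(C)c1cc(NC(=O)Nc2cc(C(F)(F)F)cc(C(F)(F)F)c2)n(-c2ccccc2)n1` gives 0 degrees C.
Compound 3 `Cc1cc(C)cc(NC(=O)Nc2cc(C(C)(C)C)nn2-c2ccccc2)c1` gives 2.4 degrees C.

Among these three numbers compound 3 stands second highest: compound 2 lies a little beneath it, while compound 1 lies well above it, as the step of a number 4.7 degrees C lower from compound 1 to compound 3 (beyond the scatter) shows. Compound 4 `COc1cccc(NC(=O)Nc2cc(C(C)(C)C)nn2-c2ccccc2)c1` differs from compound 3 by 3-methoxyphenyl in place of 3,5-dimethylphenyl on an amide-type nitrogen. Among the compounds with values here, the only measured step concerns a different exchange of groups on the same nitrogen and so gives no direct guide to this one; it shows merely that such exchanges can shift the read-out in this assay by a large amount. A moderate step with no clear direction is therefore expected, and compound 4 is estimated at 3 degrees C, within 0.5 degrees C to 6 degrees C. The expected change amounts to a number 0.60 degrees C higher from compound 3 to compound 4 (within the scatter).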

Compound 4, shift of the target's melting temperature: 3.6 degrees C
Beside the measured number, compound 4's estimate is 0.60 degrees C below it, and the stated range covers the measured number.
By their numbers in this assay, from the lowest: compound 2; then compound 3; then compound 4; then compound 1.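

On this amide-type nitrogen, 3-methoxyphenyl in place of 3,5-dimethylphenyl gives a number 1.2 degrees C higher from compound 3 to compound 4 (beyond the scatter) in this assay, so a change between two groups of the same heavy-atom count can still move the read-out beyond the scatter. The same group in place of 2-methylphenyl gives a number 3.5 degrees C lower from compound 1 to compound 4 (beyond the scatter), so 3-methoxyphenyl recovers only part of the gap to compound 1. Nothing available explains either step. On these data alone, whether an amine or a carboxylic acid in place of the methoxy group would raise the read-out remains open.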